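Replacing acetoxy with iodo on the aryl ring of compound 3

The source may hold more compounds than are shown below. What is called first, only, known or untested is meant among the compounds shown, and "the series" means these compounds.

Compound 3 `COC(=O)C1=C(C)N=C(C)/C(=C(\O)OC)C1c1cccc(OC(C)=O)c1` gives 6030 nM in a functional assay (muscle tissue) with Cavia porcellus as the target (a lower number here means that less compound is needed, a higher number that more compound is needed for the effect), the highest of the three numbers: compound 1 `COC(=O)C1=C(C)N=C(C)/C(=C(\O)OC)C1c1cccc(O)c1` gives 1000 nM and compound 2 `COC(=O)C1=C(C)N=C(C)/C(=C(\O)OC)C1c1ccc(F)cc1` gives 129 nM. The step to compound 4 `COC(=O)C1=C(C)N=C(C)/C(=C(\O)OC)C1c1cccc(I)c1` is iodo in place of acetoxy on an aromatic carbon. Within the data shown here, two measured steps bear on it. The acetoxy group itself was a liability: a 6.0-fold higher number from compound 1 to compound 3 (0.78 log units; beyond the scatter). And a halogen in place of a hydroxyl helped: a 7.8-fold lower number from compound 1 to compound 2 (0.89 log units; beyond the scatter), although that change also shifted the position of the substituent, so it informs only loosely. Removing the acetoxy should recover at least the ground lost from compound 1, and a halogen may bring a further gain as seen in compound 2. Compound 4 is therefore expected to give a substantially lower number, a 200-fold lower number from compound 3 to compound 4 (2.30 log units; beyond the scatter). The estimate for compound 4 in this assay is 30 nM, with a range of 4 nM to 250 nM.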

Compound 4, half-maximal effective concentration: 41.7 nM
For compound 4 the middle estimate is 1.4-fold (0.14 log units) below the measured one; measured number inside the range.
By their numbers in this assay, from the lowest: compound 4; then compound 2; then compound 1; then compound 3.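

In this assay the iodo group on this aromatic carbon does far more than undo the cost of the acetoxy group (a 140-fold lower number from compound 3 to compound 4 (2.16 log units; beyond the scatter)). It also improves on the hydroxy group held at the same place (a 24-fold lower number from compound 1 to compound 4 (1.38 log units; beyond the scatter)), so the gain cannot be read as a mere return to the level of the free hydroxy compound. Compound 4 also falls below the 4-fluorophenyl compound (a 3.1-fold lower number from compound 2 to compound 4 (0.49 log units; beyond the scatter)), which gives it the lowest number of the four, though that step changes both the halogen and its place on the ring, and nothing available explains the gain.

The compounds shown leave open whether chloro, bromo or methyl on this same carbon would match iodo. They also leave open whether fluoro here would behave as iodo does, or whether an amine would be tolerated.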